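The compounds below may be only part of what the source reports. "The series", "measured", "known", "first", "only" and "open" are said of these compounds alone.

Compound 3 `O=C(NNC(=S)Nc1csc(-c2ccccc2)c1)c1ccc(O)cc1` gives 40000 nM in a functional assay on B16-F10 cells (Mus musculus) for inhibition, read by colorimetric assay and MTT assay, with a stated time of 72 h (on this read-out higher numbers stand for weaker inhibition and lower numbers for stronger inhibition), the highest of the three numbers recorded there. Compound 1 `Cc1ccc(C(=O)NNC(=S)Nc2csc(-c3ccc(C)cc3)c2)cc1` gives 20000 nM in this assay, which lies within the scatter of the value of compound 3, whereas compound 2 `COc1ccc(C(=O)NNC(=S)Nc2csc(-c3ccc(C)cc3)c2)cc1` gives 9000 nM in this assay, a gap beyond the scatter. Compound 4 `Cc1ccc(-c2cc(NC(=S)NNC(=O)c3ccc(O)cc3)cs2)cc1` has not yet been measured. It differs from compound 3 by methyl in place of hydrogen on an aromatic carbon, on an aromatic carbon of a six-membered aromatic ring of carbon only, para to a large group; cut one bond further out, the change reads phenyl to 4-methylphenyl. Among the measured compounds shown here, the only single-point step recorded, a 2.2-fold lower number from compound 1 to compound 2 (0.35 log units; beyond the scatter), concerns methoxy in place of methyl, a different change, and does not bear directly on methyl entering in place of hydrogen. For the measured compounds named here, no measured pair isolates this change, so no step beyond the scatter is expected in this assay. Compound 4 is therefore expected to give about 30000 nM, with a range from 12000 nM to 75000 nM. This estimate implies a step of a 1.3-fold lower number from compound 3 to compound 4 (0.12 log units; within the scatter), expected to remain within the scatter.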

Compound 4, half-maximal inhibitory concentration: 48000 nM
The estimate for compound 4 lay 1.6-fold (0.20 log units) below the measured number; the range from low to high includes it.
By their numbers in this assay, from the lowest: compound 2; then compounds 1, 3 and 4 (each within the scatter of the next, the first and the last beyond it).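

Methyl in place of hydrogen on the six-membered aromatic ring, para to a large group, gives a 1.2-fold higher number from compound 3 to compound 4 (0.08 log units; within the scatter) in this assay and so stays within the scatter. Among the compounds shown here, this is the only pair that isolates phenyl to 4-methylphenyl, and it shows that this position takes a methyl with no change that can be told from repeat measurement. With the 4-methylphenyl in place, the steps beyond the scatter come from changes elsewhere, with a 5.3-fold higher number from compound 2 to compound 4 (0.73 log units; beyond the scatter) for hydrogen in place of methyl on an oxygen and a 2.4-fold higher number from compound 1 to compound 4 (0.38 log units; beyond the scatter) where a methyl on an aromatic carbon gives way to a hydroxy.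

As far as these compounds go, whether a chlorine, an amine or a longer chain at this position would also stay within the scatter remains open. Nothing available explains any of these steps.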